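The source may report more compounds than this note shows. Statements on the series, on what has been measured and on what is new or still open speak of the compounds shown alone.

In a functional assay on NCI-H1299 cells (Homo sapiens), read by flow cytometry (a lower number here means that less compound is needed, a higher number that more compound is needed for the effect), compound 1 `CCOc1ccc2c(c1)NC(=O)Nc1cnc(C#N)c(n1)OCC/C=C\CO2` gives only a limit, > 10000 nM. Compound 2 `Cc1ccc2c(c1)NC(=O)Nc1cnc(C#N)c(n1)OCC/C=C\CO2` also gives only a limit, > 10000 nM. Among the compounds with values here, the one measured change is a step that the two limits leave unreadable from compound 1 to compound 2, so it offers no size to carry forward. Compound 3 `N#Cc1ncc2nc1OCC/C=C\COc1ccc(CCOC3CCCCO3)cc1NC(=O)N2` differs from compound 2 by ((oxan-2-yl)oxy)methyl in place of hydrogen on a saturated chain carbon bound to an aromatic carbon. Within the data shown here, the only guide is the limit of > 10000 nM in this assay, at which 2 of the 2 values shown sit, and it points to no gain in this assay. The expected result is a number no higher from compound 2 to compound 3 (the limit leaves the size open), with no clear shift in either direction. For compound 3 the estimated value is 10000 nM, with an expected range of 3000 nM to 30000 nM, and another limit is likely.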

Compound 3, half-maximal effective concentration: > 10000 nM
Compound 3: no number, only a limit; the forecaster's own chance of this, stated with the estimate: 70%; the middle value sits exactly at the limit.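

Compound 1, compound 2 and compound 3 each give only a limit, not a number, so no step among them can be read: the limit of > 10000 nM in this assay, at which 3 of the 3 values shown sit.

The compounds shown leave open how much of each is needed for the effect in this assay, and whether these changes alter that amount.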